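The source may report more compounds than this note shows. Statements on the series, on what has been measured and on what is new or still open speak of the compounds shown alone.

Compound 1 `COc1ccc(C(=O)c2cc(OC)c(OC)c(OC)c2)cc1N` gives 30 nM in a functional assay on B16 cells (Mus musculus) for cytotoxicity, read by MTT assay, with a stated time of 72 h; a higher number here means a weaker inhibitor, a lower number a stronger inhibitor. Compound 2 `C#CCOc1cccc(/C=C/C(=O)Nc2cc(C(=O)c3cc(OC)c(OC)c(OC)c3)ccc2OC)c1` gives 12200 nM in this assay, the highest of the two numbers, set far apart from compound 1. Compound 3 `COc1ccc(C(=O)c2cc(OC)c(OC)c(OC)c2)cc1NC(=O)/C=C/c1ccc(F)cc1` has not yet been measured in this assay. It differs from compound 2 by 4-fluorophenyl in place of 3-(propargyloxy)phenyl on a double-bonded chain carbon bound to a double-bonded chain carbon. Compound 3 keeps the amide linkage that compound 2 carries, so it is expected to stay near compound 2, with a step of a 1.5-fold lower number from compound 2 to compound 3 (0.18 log units; within the scatter) that may not reach beyond the scatter. Compound 3 is therefore estimated at 8000 nM, within a range of 1500 nM to 40000 nM.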

Compound 3, half-maximal inhibitory concentration: 400 nM
Beside the measured number, compound 3's estimate is 20-fold (1.30 log units) above it, outside the stated range (below it).
By their numbers in this assay, from the lowest: compound 1; then compound 3; then compound 2.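

The group on the double-bonded chain carbon strongly affects the result in this assay: with the amide linkage kept, 4-fluorophenyl in place of 3-(propargyloxy)phenyl gives a 31-fold lower number from compound 2 to compound 3 (1.48 log units; beyond the scatter). Even so, (2-(4-fluorophenyl)ethenyl)carbonyl in place of hydrogen on the nitrogen still gives a 13-fold higher number from compound 1 to compound 3 (1.12 log units; beyond the scatter), so neither acylated compound matches the core of compound 1. Nothing measured here explains either step. The compounds shown do not separate the effect of adding fluorine from that of losing the propargyloxy group. A plain phenyl at this place would help to separate them.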